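Series notes: replacing the 4-bromophenyl arm of compound 1

A few compounds are considered here, and "the series" means these few. Any claim that something is new, unique, unknown or untested is made for them only; others in the source may bear on it.

Measured so far in a functional assay on HT-29 cells (Homo sapiens) for inhibition, read by MTT assay, with a stated time of 48 h; a lower number here means a stronger inhibitor, a higher number a weaker inhibitor:
compound 1 `COc1cc(-c2cc(-c3ccc(Br)cc3)nc(-c3ccccc3)n2)cc(OC)c1OC`: 3170 nM
compound 2 `COc1cc(-c2cc(-c3cccc(O)c3)nc(-c3ccccc3)n2)cc(OC)c1OC`: reported only as a limit, > 25000 nM
compound 3 `COc1ccc(-c2cc(-c3cc(OC)c(OC)c(OC)c3)nc(-c3ccccc3)n2)cc1`: 4230 nM

Compound 1 holds the lowest of the two numbers; compound 3 is nearest, with a 1.3-fold higher number from compound 1 to compound 3 (0.13 log units; within the scatter). For compound 2 the assay returns a limit and no number (the limit of > 25000 nM in this assay, at which 1 of the 3 values shown sits). The two swaps at the same aromatic carbon therefore split: methoxy in place of bromo is a 1.3-fold higher number from compound 1 to compound 3 (0.13 log units; within the scatter), whereas 3-hydroxyphenyl in place of 4-bromophenyl is an at least 7.8-fold higher number from compound 1 to compound 2 (0.89 log units; beyond the scatter), and going back from compound 2 to compound 3 is an at least 5.9-fold lower number from compound 2 to compound 3 (0.77 log units; beyond the scatter).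

Compound 4 `COc1cc(-c2cc(-c3cccs3)nc(-c3ccccc3)n2)cc(OC)c1OC`, not yet measured, carries thiophen-2-yl in place of 4-bromophenyl on an aromatic carbon. Within the data shown here, no measured step contains thiophen-2-yl, so the bearing is indirect: a six-membered carbon ring with a halogen or methoxy kept the number low, while the one other departure from that pattern, compound 2, lost potency beyond the scatter. A modest weakening for compound 4 is expected, a 1.7-fold higher number from compound 1 to compound 4 (0.24 log units; within the scatter). In this assay compound 4 is estimated at 5500 nM, with a range of 2000 nM to 16000 nM.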

Compound 4, half-maximal inhibitory concentration: > 25000 nM
Compound 4 was reported as a limit (the forecaster's own chance of this, stated with the estimate: 12%); middle value at least 4.5-fold (0.65 log units) from the limit.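

In this assay, thiophen-2-yl in place of 4-bromophenyl gives an at least 7.8-fold higher number from compound 1 to compound 4 (0.89 log units; beyond the scatter), and thiophen-2-yl in place of 4-methoxyphenyl gives an at least 5.9-fold higher number from compound 3 to compound 4 (0.77 log units; beyond the scatter). The loss at this aromatic carbon is therefore not confined to the hydroxy-bearing arm of compound 2, since compound 4 carries no hydroxy group and also returns a limit rather than a number: the limit of > 25000 nM in this assay, at which 2 of the 4 values shown sit. Of the four arms shown, only the 4-bromophenyl of compound 1 and the 4-methoxyphenyl of compound 3 give a number, and these two lie within the scatter of each other.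

On these data alone, how far compound 2 and compound 4 lie past the limit stays open, so the step between them cannot be read. Also open, as far as these compounds go, is whether a 4-aminophenyl or a pyridin-3-yl arm would return a number.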